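The compounds below may be only part of what the source reports. "The series", "measured", "known", "first", "only" and "open" are said of these compounds alone.

Measured compounds:
compound 1, `Cc1ccccc1-c1nnc(SCCn2c([N+](=O)[O-])cnc2C)o1`: 5100 nM
compound 2, `Cc1ccc(-c2nnc(SCCn3c([N+](=O)[O-])cnc3C)o2)c(O)c1`: 16600 nM

Both numbers come from a functional assay on HepG2 cells (Homo sapiens) for cytotoxicity, read by MTT assay, with a stated time of 48 h; a higher number here means a weaker inhibitor, a lower number a stronger inhibitor. Compound 1 holds the lowest number of the two. Going by the values given here, the only measured step is a 3.3-fold higher number from compound 1 to compound 2 (0.51 log units; beyond the scatter), a modest loss on exchanging the aryl group on the same aromatic carbon of the shared core.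

Compound 3, `Cc1ncc([N+](=O)[O-])n1CCSc1nnc(-c2ccccn2)o1`, has not yet been measured in this assay . Its difference from compound 1 is pyridin-2-yl in place of 2-methylphenyl on an aromatic carbon. Among the compounds with values here, the one measured step that bears on it is the step from compound 1 to compound 2, where a different exchange of the same aryl group gave a modest loss. Within the data shown here, no measured compound shows how the pyridin-2-yl group itself behaves on this core. A change of comparable size is taken as the expectation, in the direction of a higher number, though a step within the scatter cannot be ruled out. The step from compound 1 to compound 3 is therefore expected to be a 1.8-fold higher number from compound 1 to compound 3 (0.25 log units; within the scatter). Compound 3 is estimated at 9000 nM, with a range from 3500 nM to 25000 nM.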

Compound 3, half-maximal inhibitory concentration: 20200 nM
Compound 3: the middle estimate sits 2.2-fold (0.35 log units) below what was measured, and the stated range covers the measured number.
By their numbers in this assay, from the lowest: compound 1; then compounds 2 and 3 (each within the scatter of the next).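

In this assay pyridin-2-yl in place of 2-methylphenyl gives a 4.0-fold higher number from compound 1 to compound 3 (0.60 log units; beyond the scatter) and so counts as a second replacement at this position that leaves the number higher, with compound 1 remaining the lowest of the three since its steps to both others lie beyond the scatter. The two replacements cannot be told apart, as a 1.2-fold higher number from compound 2 to compound 3 (0.09 log units; within the scatter) shows, even though pyridin-2-yl has a ring nitrogen and 2-hydroxy-4-methylphenyl has a carbon-only ring with a hydroxyl and a methyl, so within these compounds only the 2-methylphenyl group stands apart. Nothing available bears on the reason for either step.

With only three aryl groups shown, it remains open whether the methyl of compound 1 matters at all, which a plain phenyl group would test, and whether a 2-aminophenyl group would stay near compound 1 or near compound 3. A pyridin-3-yl or pyridin-4-yl group would show whether the result for compound 3 belongs to pyridine rings in general or to pyridin-2-yl alone.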